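Trimming the Carbonyl Substituent in Compound 4

The source may hold more compounds than are shown below. What is called first, only, known or untested is meant among the compounds shown, and "the series" means these compounds.

Of the compounds shown here, three sharing one core have been tested in an assay on isolated protein with Bile acid receptor (Homo sapiens) as the target; a lower number here means that less compound is needed, a higher number that more compound is needed for the effect. Compound 1 `COC(=O)/C=C/c1cccc(N(Cc2ccc(/C=C/c3c(Cl)cccc3Cl)cc2)C(=O)C(C)C)c1` gives 195 nM, compound 2 `COC(=O)/C=C/c1cccc(N(Cc2ccc(-c3ccc(SC)cc3)cc2)C(=O)C(C)C)c1` gives 51 nM, and compound 3 `COC(=O)/C=C/c1cccc(N(Cc2ccc(-c3ccc(OC)cc3)cc2)C(=O)C2CCCCC2)c1` gives 89 nM. Among the compounds with values here, the only measured step, a 3.8-fold lower number from compound 1 to compound 2 (0.58 log units; beyond the scatter), changes a group on the aromatic carbon, not the group on the carbonyl carbon. Compound 3 stands second highest of the three numbers; its gap to compound 2 lies within the scatter, while its gap to compound 1 lies beyond it. Compound 4 `COC(=O)/C=C/c1cccc(N(Cc2ccc(-c3ccc(OC)cc3)cc2)C(=O)C(C)C)c1` differs from compound 3 by isopropyl in place of cyclohexyl on a carbonyl carbon. Within the data shown here, no measured step touches the carbonyl carbon, so no shift beyond the scatter is expected in this assay. Compound 4 is estimated at 80 nM, between 30 nM and 250 nM, an expected 1.1-fold lower number from compound 3 to compound 4 (0.05 log units; within the scatter).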

Compound 4, half-maximal effective concentration: 97 nM
For compound 4 the middle estimate is 1.2-fold (0.08 log units) below the measured one; measured number inside the range.
By their numbers in this assay, from the lowest: compounds 2, 3, 4 and 1 (each within the scatter of the next, the first and the last beyond it).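

In this assay the carbonyl carbon takes isopropyl in place of cyclohexyl with a step inside the scatter (a 1.1-fold higher number from compound 3 to compound 4 (0.04 log units; within the scatter)), so at this position the ring can go without a change that can be told from noise. Methoxy in place of methylsulfanyl (a 1.9-fold higher number from compound 2 to compound 4 (0.28 log units; within the scatter)) and 4-methoxyphenyl in place of 2-(2,6-dichlorophenyl)ethenyl (a 2.0-fold lower number from compound 1 to compound 4 (0.30 log units; within the scatter)) also stay inside the scatter. Nothing available here explains this tolerance. Going by these compounds, whether the carbonyl carbon would accept a plain methyl, or a group carrying an amine, remains open.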